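This account rests on a few compounds, and the source may have more. Where it says the series, first, only, none or still open, it means among the compounds named here.

Two compounds of the series have been run through a functional assay on SK-MEL-5 cells (Homo sapiens) for inhibition, read by sulforhodamine B assay, with a stated time of 48 h (on this read-out higher numbers stand for weaker inhibition of growth and lower numbers for stronger inhibition of growth), so far. Compound 1, `COc1ccc(-c2ccc(-c3ccc(C(=N)N)cc3)s2)cc1`, gives 1390 nM in this assay and has the lowest of the two numbers. Compound 2, `N=C(N)c1ccc(-c2ccc(-c3cc(Cl)cc(Cl)c3)s2)cc1`, gives 1600 nM in this assay, a number that lies within the scatter of compound 1, so no order between the two can be read.

Compound 3, `N=C(N)c1ccc(-c2ccc(-c3ccc(F)cc3)s2)cc1`, is the next to be measured. It differs from compound 1 in one place: fluoro in place of methoxy on an aromatic carbon. The two measured compounds do not offer a step of this kind, so nothing measured bears directly on the change from methoxy to fluoro.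

The step of a 1.3-fold higher number from compound 1 to compound 3 (0.11 log units; within the scatter) is expected to be small, if anything toward a weaker inhibition of growth, and within the scatter. For compound 3 the expected value is 1800 nM, with a range from 800 nM to 4000 nM.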

Compound 3, concentration for 50% growth inhibition: 1600 nM
For compound 3 the middle estimate is 1.1-fold (0.05 log units) above the measured one; the measured number falls inside the stated range.
By their numbers in this assay, from the lowest: compounds 1, 2 and 3 (each within the scatter of the next).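

In this assay, fluoro in place of methoxy on this aromatic carbon, para to a large group, gives a 1.2-fold higher number from compound 1 to compound 3 (0.06 log units; within the scatter). For the compounds shown here, this is the first one-place change read at this position, and it shows that going from methoxy to the smaller fluoro, with the hydrogen-bond acceptor counted on methoxy gone, leaves the two compounds unseparated on this read-out. Nothing measured bears on why they read alike.

Still open, on these data alone, is whether any group at this carbon moves the number beyond the scatter: an amine, a carboxylic acid or a longer alkoxy chain would test that. A single pair also leaves open whether methoxy and fluoro read alike when another part of the core of compound 1 is changed.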